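Chloro in place of nitro on the anilide of compound 3

This account rests on a few compounds, and the source may have more. Where it says the series, first, only, none or still open, it means among the compounds named here.

This account follows a single change among thiadiazole thioacetanilides. Compound 1 `O=C(CSc1snnc1-c1ccccc1)Nc1ccccc1Cl` in an ADME assay on MT4 cells (Homo sapiens) for cytotoxicity (a higher number here means that more compound is tolerated, a lower number that less compound is tolerated), gives > 345000 nM, which is a limit of the assay rather than a number. Compound 2 `COc1ccc(-c2nnsc2SCC(=O)Nc2ccccc2Cl)cc1` in this assay gives > 318000 nM, again a limit of the assay. The step from compound 1 to compound 2 is a step that the two limits leave unreadable from compound 1 to compound 2. Going by the values given here, compound 3 `O=C(CSc1snnc1-c1ccc(F)cc1F)Nc1ccccc1[N+](=O)[O-]` in this assay gives 165000 nM, the only plain number among the three measured compounds.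

Compound 4 `O=C(CSc1snnc1-c1ccc(F)cc1F)Nc1ccccc1Cl` differs from compound 3 by chloro in place of nitro on an aromatic carbon. Among the compounds with values here, no measured step bears directly on this exchange, since no measured pair differs by nitro against chloro alone. What the numbers do show is that compound 1, which carries the same chloro group on the anilide, sits at the limit of > 345000 nM in this assay, at which 1 of the 3 values shown sits, and compound 2 at the limit of > 318000 nM in this assay, at which 1 of the 3 values shown sits. Compound 4 is therefore expected to be tolerated at least as well as compound 3, with a step of a 1.8-fold higher number from compound 3 to compound 4 (0.26 log units; within the scatter) toward higher values, and it may well reach a limit again. The estimate for compound 4 in this assay is 300000 nM, with a range from 120000 nM to 650000 nM.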

Compound 4, half-maximal cytotoxic concentration: 178000 nM
For compound 4 the middle estimate is 1.7-fold (0.23 log units) above the measured one, and the stated range covers the measured number.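

In this assay, going by these compounds alone, the change from 2-nitrophenyl to 2-chlorophenyl gives the one plainly readable step at this position, a 1.1-fold higher number from compound 3 to compound 4 (0.03 log units; within the scatter). With 2,4-difluorophenyl held in place, the two anilides therefore cannot be told apart here, even though nitro brings more heavy atoms and hydrogen-bond acceptors than chloro. Compound 4 also gives the 2-chlorophenyl anilide its first plain number, which turns the comparisons with the other two compounds carrying that anilide into floors only: an at least 1.7-fold lower number from compound 2 to compound 4 (0.25 log units; that floor lies within the scatter), and an at least 1.9-fold lower number from compound 1 to compound 4 (0.28 log units; that floor lies within the scatter). Both floors lie within the scatter and rest on limits of the assay, so they do not show that 2,4-difluorophenyl lowers the number relative to 4-methoxyphenyl or phenyl.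

From the compounds shown here alone, it remains open whether the same place on the anilide would read the same with an amine or a carboxylic acid in place of nitro or chloro. Going by these compounds, it is also open whether the exchange of nitro for chloro would stay as small with phenyl or 4-methoxyphenyl on the shared core instead of 2,4-difluorophenyl.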